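Adding a Propyl Group to a Chromone Antagonist

The source may report more compounds than this note shows. Statements on the series, on what has been measured and on what is new or still open speak of the compounds shown alone.

Measured so far, in a functional assay on ileum (Cavia porcellus) for antagonist activity, with a stated time of 30 s; on this read-out higher numbers stand for weaker inhibition and lower numbers for stronger inhibition:
compound 1, `CC(=O)c1ccc(OCC(O)COc2ccc3c(=O)cc(C(=O)O)oc3c2)cc1O`, gives 28 ug/mL
compound 2, `CCCc1c(OCC(O)COc2ccc3c(=O)cc(C(=O)O)oc3c2)ccc(C(C)=O)c1O`, gives 0.08 ug/mL
compound 3, `CCCc1ccccc1OCC(O)COc1ccc2c(=O)cc(C(=O)O)oc2c1`, gives 2 ug/mL

Compound 1 and compound 2 differ in one place, (propyl in place of hydrogen on an aromatic carbon). That change made a large step, a 350-fold lower number from compound 1 to compound 2 (2.54 log units; beyond the scatter). Compound 3 differs from compound 1 in its side chain, (2-propylphenyl in place of 4-acetyl-3-hydroxyphenyl on an oxygen on a saturated carbon), and this also lowered the number, a 14-fold lower number from compound 1 to compound 3 (1.15 log units; beyond the scatter). In this assay compound 3 therefore stands with a lower number than compound 1 and a higher number than compound 2.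

Compound 4, `CCCc1ccccc1OCC(O)COc1cc2oc(C(=O)O)cc(=O)c2cc1CCC`, has not yet been measured. It differs from compound 3 by propyl in place of hydrogen on an aromatic carbon. For the measured compounds named here, this is the same kind of change as the one from compound 1 to compound 2, but not the same: there the propyl entered ortho to a hydroxy group and meta to an acetyl group on a single ring, whereas here it enters a ring that is part of a fused system of two rings, meta and para to the fused ring. Going by the values given here, because the only measured example of this change is a 350-fold lower number from compound 1 to compound 2 (2.54 log units; beyond the scatter), a lower number is expected for compound 4, yet the different surroundings make a smaller step the safer estimate. The step from compound 3 to compound 4 is expected to be a 6.7-fold lower number from compound 3 to compound 4 (0.82 log units; beyond the scatter). Compound 4 is thus estimated at 0.3 ug/mL, likely somewhere from 0.05 ug/mL to 1.5 ug/mL.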

Compound 4, half-maximal inhibitory concentration: 1.6 ug/mL
Estimate against measurement, compound 4: 5.3-fold (0.73 log units) below; the whole stated range lies below it.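

In this assay, the new step is a 1.3-fold lower number from compound 3 to compound 4 (0.10 log units; within the scatter), so on this core the propyl group brings no difference that can be told apart from the ordinary spread of repeated measurements. This shows that a change which looks identical on paper need not carry its effect from one core to another in this series, and that the large gain seen on the core of compound 1 cannot simply be added onto a related compound. It does not show why, since two examples cannot separate the ring that receives the propyl from the rest of the molecule, such as the 2-propylphenyl group that compound 3 already carries, and the gap between the two steps stands only as a measured fact: the same change on two cores in this assay, a 350-fold lower number (2.54 log units; beyond the scatter) from compound 1 to compound 2 and a 1.3-fold lower number (0.10 log units; within the scatter) from compound 3 to compound 4, 280-fold (2.45 log units) apart, beyond the scatter of two such steps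

The compounds shown leave open whether a shorter chain such as ethyl, or a longer chain such as butyl, placed where the propyl sits in compound 4 would give a number different from that of compound 3. They also leave open whether a non-carbon substituent there, such as a chlorine atom or a methoxy group, would behave any differently.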